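Shared core series: chloro to acetyl on the aromatic ring

The compounds below may be only part of what the source reports. "The series", "measured", "known", "first", "only" and "open" are said of these compounds alone.

Measured so far in an assay on isolated protein for inhibition of Polyunsaturated fatty acid 5-lipoxygenase (Homo sapiens); on this read-out higher numbers stand for weaker inhibition and lower numbers for stronger inhibition:
- compound 1 `CCc1ccccc1N1CCCC(=O)N1` gives 39000 nM
- compound 2 `O=C1CCCN(c2ccccc2Cl)N1` gives 99000 nM
- compound 3 `O=C1CCCN(c2cccc(Cl)c2)N1` gives 2500 nM

Compound 3 stands lowest of the three numbers; compound 1 is nearest with a higher number and compound 2 furthest with a still higher number, both gaps beyond the scatter. Among the measured compounds shown here, the only one-place step measured, a 2.5-fold higher number from compound 1 to compound 2 (0.40 log units; beyond the scatter), concerns chloro in place of ethyl on an aromatic carbon and is modest. Compound 1 and compound 3 carry different groups at different positions, so their values are compared without a single-change step.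

The next compound, compound 4 `CC(=O)c1cccc(N2CCCC(=O)N2)c1`, differs from compound 3 by acetyl in place of chloro on an aromatic carbon. For the measured compounds named here, no measured step covers an acetyl entering, nor a chloro leaving from the position it holds in compound 3. Going by the values given here, the one step that exists, a 2.5-fold higher number from compound 1 to compound 2 (0.40 log units; beyond the scatter), changes a group at another place and gives no direction for this exchange. A step of unknown direction from compound 3 is therefore expected in this assay, with the range set wide.

Compound 4 is estimated at 5000 nM, with a range from 1500 nM to 25000 nM. The estimate for compound 4 means an expected step of a 2.0-fold higher number from compound 3 to compound 4 (0.30 log units; within the scatter).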

Compound 4, half-maximal inhibitory concentration: 19000 nM
The estimate for compound 4 lay 3.8-fold (0.58 log units) below the measured number; low and high end bracket the measured number.
By their numbers in this assay, from the lowest: compound 3; then compound 4; then compound 1; then compound 2.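

In this assay, among the compounds shown here, acetyl in place of chloro on this aromatic carbon, meta to a group of 7 heavy atoms, gives a 7.6-fold higher number from compound 3 to compound 4 (0.88 log units; beyond the scatter), the first measured step at this position; the exchange therefore has a direction, and of the two groups, chloro goes with the lower number. The exchange alters several counted features at once: chloro has 1 heavy atom and 0 hydrogen-bond acceptors, while acetyl has 3 heavy atoms, 1 hydrogen-bond acceptor and 1 double bond outside aromatic rings, and this single pair cannot show which of these differences, if any, matters. No available measurement bears on why the number rises with this exchange.

Going by these compounds, it remains open whether any group at this place would give a lower number than chloro, for example methoxy, an amine, a carboxylic acid or a longer alkyl chain, and whether such groups would follow the direction seen with acetyl. On these data alone, it also remains open whether acetyl would give a step of similar direction and size at the place that chloro holds in compound 2.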